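The compounds below may be only part of what the source reports. "The series", "measured", "known", "first", "only" and "open" are said of these compounds alone.

Compound 1 `CCOC(=O)c1c(-c2cc(F)cc(OC)c2)[nH]c2cc(OC)ccc2c1=O` — > 21500 nM
Compound 2 `CCOC(=O)c1c(-c2ccccc2)[nH]c2cc(OC)ccc2c1=O` — > 21500 nM
Compound 3 `CCOC(=O)c1c(-c2cccc(OC)c2)[nH]c2cc(OC)ccc2c1=O` — > 21500 nM

These readings come from an ADME assay on BJ cells (Homo sapiens) for cytotoxicity, read by luminescence, with a stated time of 72 h; a higher number here means that more compound is needed for the effect, a lower number that less compound is needed. For compound 1 the reading > 21500 nM is a limit of the assay, not a number. The readings of compound 2 and compound 3 are limits as well, so compound 1 stands with them at the limit of > 21500 nM in this assay, at which 3 of the 3 values shown sit, and no order among the three can be read. Compound 4 `CCOC(=O)c1c(-c2cccc(C(C)=O)c2)[nH]c2cc(OC)ccc2c1=O` differs from compound 1 by 3-acetylphenyl in place of 3-fluoro-5-methoxyphenyl on an aromatic carbon. The measured steps that bear on this change are a step that the two limits leave unreadable from compound 1 to compound 2, a step that the two limits leave unreadable from compound 1 to compound 3 and a step that the two limits leave unreadable from compound 2 to compound 3; none gives a size or a direction, so no step beyond the scatter can be foreseen. Compound 4 is therefore expected to sit at the limit too, estimated at 30000 nM within 15000 nM to 80000 nM, a step that the limit leaves unreadable from compound 1 to compound 4.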

Compound 4, half-maximal effective concentration: > 21500 nM
Compound 4 gave a limit, no number (the forecaster's own chance of this, stated with the estimate: 85%); the middle value does not contradict the limit.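

Compound 4 gives only a limit, as do compound 1, compound 2 and compound 3, so no step between them can be read: the limit of > 21500 nM in this assay, at which 4 of the 4 values shown sit.

The compounds shown leave open whether these four differ at all in this assay.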